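Replacing carboxy with hydroxymethyl in the amide side chain

The compounds below may be only part of what the source reports. "The series", "measured", "known", "first", "only" and "open" are said of these compounds alone.

Measured so far in a functional assay on HepG2 cells (Homo sapiens) for antiproliferative activity, read by MTT assay, with a stated time of 48 h; a higher number here means a weaker inhibitor, a lower number a stronger inhibitor
compound 1 `CCOC(=O)C(CC(=O)OC)NC(=O)c1ccc(C(CC)(CC)c2ccc(OCCC(O)(CC)CC)c(C)c2)n1CC` gives > 50000 nM as a limit of the assay, not a number
compound 2 `CCn1c(C(=O)NC(CC(=O)O)C(=O)OC)ccc1C(CC)(CC)c1ccc(OCCC(O)(CC)CC)c(C)c1` gives 10700 nM
compound 3 `CCn1c(C(=O)NC(C)C(=O)O)ccc1C(CC)(CC)c1ccc(OCCC(O)(CC)CC)c(C)c1` gives 1740 nM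

Compound 3 holds the lowest number of the series at 1740 nM, and its steps to both other compounds lie beyond the scatter. Compound 4 `CCn1c(C(=O)NC(C)CO)ccc1C(CC)(CC)c1ccc(OCCC(O)(CC)CC)c(C)c1` comes from compound 3 by one change, (hydroxymethyl in place of carboxy on a saturated chain carbon bound to an amide-type nitrogen and a saturated chain carbon), with hydroxymethyl in place of carboxy on a saturated chain carbon bound to an amide-type nitrogen and a saturated chain carbon. Within the data shown here, no measured step makes this exchange. The nearest guides are a 6.1-fold lower number from compound 2 to compound 3 (0.79 log units; beyond the scatter) and an at least 28-fold lower number from compound 1 to compound 3 (1.45 log units; beyond the scatter), and in both a smaller group on the amide-type nitrogen gave a lower number. Neither step isolates carboxy, so they set no direction for compound 4 and only a loose width for the estimate. In this assay the expected step is modest at most, and the estimate is a 1.4-fold higher number from compound 3 to compound 4 (0.16 log units; within the scatter). For compound 4 the estimated value is 2500 nM, with an expected range of 600 nM to 12000 nM.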

Compound 4, half-maximal inhibitory concentration: 43100 nM
The estimate for compound 4 lay 17-fold (1.24 log units) below the measured number; the whole stated range lies below it.
By their numbers in this assay, from the lowest: compound 3; then compound 2; then compound 4. At a limit, above all of these: compound 1.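

In this assay, hydroxymethyl in place of carboxy on this saturated chain carbon gives a large step, a 25-fold higher number from compound 3 to compound 4 (1.39 log units; beyond the scatter), and this is the only step shown that isolates carboxy. Compound 4 also breaks the earlier run in which a smaller group on the amide-type nitrogen gave a lower number, as a 4.0-fold higher number from compound 2 to compound 4 (0.61 log units; beyond the scatter), even though its group is the smaller one. Only a floor can be given for the remaining step, an at least 1.1-fold lower number from compound 1 to compound 4 (0.06 log units; that floor lies within the scatter). The value of compound 1 is a limit of the assay: the limit of > 50000 nM in this assay, at which 1 of the 4 values shown sits.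

The compounds shown leave open whether the lower number needs carboxy itself or would survive with a primary carboxamide or a tetrazole on this carbon. A methyl ester at the same place would also show whether the free acid is required.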